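Amide aryl swap in a low-toxicity monocyte series

The compounds below may be only part of what the source reports. "The series", "measured", "known", "first", "only" and "open" are said of these compounds alone.

Compound 1 `COc1ccc(-c2cnc(NC(=O)c3ccno3)n2C)cc1` carries a 1,2-oxazol-5-yl group on its amide carbonyl. In a toxicity assay on THP-1 cells (Homo sapiens) for inhibition (on this read-out higher numbers stand for lower toxicity in this test and lower numbers for higher toxicity in this test), compound 1 reaches only the limit of the test, > 100000 nM. Compound 2 `Cn1c(-c2ccc(C#N)cc2)cnc1NC(=O)c1ncc[nH]1` differs from compound 1 in more than one place and is not treated as a step. In this assay compound 2 likewise stops at the limit, > 100000 nM. Both values shown therefore sit at the same ceiling (the limit of > 100000 nM in this assay, at which 2 of the 2 values shown sit), so compound 1 stands level with the rest of the measured set and no ranking can be drawn from it.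

Compound 3 `COc1ccc(-c2cnc(NC(=O)c3ccccc3OC)n2C)cc1` is not yet measured. It arises from compound 1 by 2-methoxyphenyl in place of 1,2-oxazol-5-yl on a carbonyl carbon. Among the compounds with values here, no measured pair differs in one place only, so the size of such a change cannot be read from data. Compound 1 itself gives only a limit, > 100000 nM. On that footing the expected step is a number no higher from compound 1 to compound 3 (the limit leaves the size open), none beyond the scatter. Compound 3 is estimated at 100000 nM, within 30000 nM to 300000 nM, and is expected most likely to be reported again as a limit.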

Compound 3, half-maximal cytotoxic concentration: > 100000 nM
Compound 3: only a limit was reported; the forecaster's own chance of this, stated with the estimate: 80%; the middle value sits exactly at the limit.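

In this assay compound 3 gives > 100000 nM, which is a limit of the test. Compound 1 also stands at a limit, so no step can be read between compound 1 and compound 3: the limit of > 100000 nM in this assay, at which 3 of the 3 values shown sit.

The compounds shown leave open whether any group on the amide carbonyl would bring a measurable value in this assay.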